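Compound 1 to compound 4: a swap on sulfur

The compounds below may be only part of what the source reports. "The series", "measured", "known", "first", "only" and "open" are said of these compounds alone.

Measured in a functional assay on U2OS cells (Homo sapiens) for antiproliferative activity, read by MTT assay, with a stated time of 72 h; a higher number here means a weaker inhibitor, a lower number a stronger inhibitor:
- compound 1 `O=C(CSc1nc2ccccc2[nH]1)Nc1ccc2nc(NC(=O)c3ccc(C(F)(F)F)cc3)sc2c1` gives 7110 nM
- compound 2 `O=C(Cn1cc(F)c(=O)n(CC(=O)Nc2ccc(Br)cn2)c1=O)Nc1ccc(Br)cn1` gives 5140 nM
- compound 3 `O=C(CSc1cccc(O)c1)Nc1ccc2nc(NC(=O)c3ccc(F)cc3)sc2c1` gives 5120 nM

Compound 1 at 7110 nM sits within the usual scatter of both compound 2 and compound 3, so these three values give no order.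

The unmeasured compound 4 `O=C(CSc1ncccn1)Nc1ccc2nc(NC(=O)c3ccc(C(F)(F)F)cc3)sc2c1` keeps the rest of compound 1 and differs in one place, with pyrimidin-2-yl in place of 1H-benzimidazol-2-yl on a sulfur. What leaves holds 1 hydrogen-bond donor and one five-membered aromatic ring with 2 hetero atoms. What enters holds 0 hydrogen-bond donors and one six-membered aromatic ring with 2 hetero atoms.

Going by the values given here, no two measured compounds differ in one place only, so the series offers no direct measure of such a change in this assay. The expectation therefore rests on compound 1 at 7110 nM and compound 3 at 5120 nM, two values within the scatter of each other. No step beyond the scatter is expected, and neither direction is favoured, so the expected change a 1.1-fold lower number from compound 1 to compound 4 (0.04 log units; within the scatter) is small. The estimate for compound 4 is 6500 nM, with an expected range from 2500 nM to 17000 nM.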

Compound 4, half-maximal inhibitory concentration: 28100 nM
Compound 4: the middle estimate sits 4.3-fold (0.64 log units) below what was measured; the whole stated range lies below it.
By their numbers in this assay, from the lowest: compounds 3, 2 and 1 (each within the scatter of the next); then compound 4.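

In this assay, the group on this sulfur matters: pyrimidin-2-yl in place of 1H-benzimidazol-2-yl gives a 4.0-fold higher number from compound 1 to compound 4 (0.60 log units; beyond the scatter), a modest step and the first in the series that lies beyond the scatter. The change is a bundle, as the group that leaves holds 9 heavy atoms, a five-membered and a six-membered aromatic ring and 1 hydrogen-bond donor, while the group that enters holds 6 heavy atoms, a single six-membered aromatic ring and 0 hydrogen-bond donors, so this one step cannot assign the loss to any one of these differences. Nothing available bears on what lies behind the higher number.

From the compounds shown here alone, whether 1H-imidazol-2-yl or 1,3-benzoxazol-2-yl on the same sulfur would fall nearer compound 1 or compound 4 remains open, and such groups would begin to separate the ring count from the hydrogen-bond donor. Also open, going by these compounds, is whether this swap gives a step of similar size when the trifluoromethyl group elsewhere in the molecule is replaced by a fluorine atom or a methoxy group.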